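Triazolylthioacetanilide series: chain substitution at the triazole nitrogen

The compounds below may be only part of what the source reports. "The series", "measured", "known", "first", "only" and "open" are said of these compounds alone.

Measured so far:
compound 1, `Cn1c(Cc2nn(C)c(=O)c3ccccc23)nnc1SCC(=O)Nc1ccc(Cl)cc1Cl`, 4500 nM
compound 2, `Cn1c(Cc2nn(C)c(=O)c3ccccc23)nnc1SCCCCCCCC(=O)Nc1ccc(Cl)cc1Cl`, 190 nM

In an assay on NK92 cells for inhibition of interleukin-15 (Homo sapiens), read by AlphaScreen, with stated times of 30 min and 1 h (on this read-out higher numbers stand for weaker inhibition and lower numbers for stronger inhibition), compound 1 gives the higher of the two numbers recorded. Compound 2, which carries the longer linker between the thioether sulfur and the anilide carbonyl, gives 190 nM, a difference that lies beyond the scatter of the measurement.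

Compound 3, `CCOC(CCn1c(Cc2nn(C)c(=O)c3ccccc23)nnc1SCC(=O)Nc1ccc(Cl)cc1Cl)OCC`, keeps the short linker of compound 1 and differs from it in one place: 2,2-diethoxyethyl in place of hydrogen on a saturated chain carbon bound to an aromatic nitrogen. Nothing measured in the series bears on a substituent at this position, so the direction of the step is open. The expectation is for a change no larger than the scatter, if any, and compound 3 is estimated at 3000 nM in this assay, within 800 nM to 10000 nM, which corresponds to an expected step of a 1.5-fold lower number from compound 1 to compound 3 (0.18 log units; within the scatter).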

Compound 3, half-maximal inhibitory concentration: > 30000 nM
Compound 3 was reported as a limit; the forecaster's own chance of this, stated with the estimate: 10%; at least 10-fold (1.00 log units) between middle value and limit.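

Putting 2,2-diethoxyethyl in place of hydrogen on the saturated chain carbon bound to an aromatic nitrogen is not a silent change in this assay: the series shows an at least 6.6-fold higher number from compound 1 to compound 3 (0.82 log units; beyond the scatter). Among these compounds, this is the first sign that the position responds to substitution, and on the short linker this substituent is not tolerated. The value of compound 3 is a limit and not a number: the limit of > 30000 nM in this assay, at which 1 of the 3 values shown sits.

The size of the loss therefore stays unknown beyond the printed step, and the compounds shown do not separate the diethoxy end from the chain length; a plain butyl chain, or an amine or a carboxylic acid at the chain end, would bear on that. Going by these compounds, whether the same substituent acts alike on the longer linker of compound 2 also stays open.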